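The compounds below may be only part of what the source reports. "The series", "measured", "known", "first", "only" and "open" are said of these compounds alone.

Of the compounds shown here, three built on a shared core have so far been tested in an ADME assay on Vero cells (Chlorocebus sabaeus) for cytotoxicity, read by resazurin assay, with a stated time of 24 h; a higher number here means that more compound is tolerated, a lower number that less compound is tolerated. Compound 1, `CC(C)CCO[C@@H]1C=CC(=O)[C@@H](COC(=O)C(C)(C)C)O1`, gives 36000 nM. Compound 2, `CC(=O)OC[C@H]1O[C@H](OC(C)C)C=CC1=O`, gives 104000 nM, and compound 3, `CC(=O)OC[C@H]1O[C@H](OCCC(C)C)C=C([C@H](O)c2ccc([N+](=O)[O-])cc2)C1=O`, gives 14300 nM. Among these three numbers compound 1 stands second highest: compound 3 sits below it by more than the scatter, and compound 2 sits above it by more than the scatter. No two of the measured compounds differ from each other in only one place, so none of these gaps can be tied to a single structural change.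

Compound 4, `CC(C)(C)C(=O)OC[C@H]1O[C@H](OCC2CC2)C=CC1=O`, has not yet been measured in this assay. It differs from compound 1 in a single place: cyclopropyl in place of isobutyl on a saturated chain carbon bound to an oxygen on a saturated carbon. Everything else in the molecule is kept as in compound 1.

Among the compounds with values here, nothing among the measured compounds tests an exchange of this kind, so there is no step here to lean on. For compound 4 the expected step from compound 1 is therefore a 1.1-fold higher number from compound 1 to compound 4 (0.02 log units; within the scatter), which I expect to lie within the scatter rather than beyond it. In this assay compound 4 is estimated to give 38000 nM, expected to fall between 15000 nM and 100000 nM.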

Compound 4, half-maximal cytotoxic concentration: 77200 nM
For compound 4 the middle estimate is 2.0-fold (0.31 log units) below the measured one, and the stated range covers the measured number.
By their numbers in this assay, from the lowest: compound 3; then compound 1; then compounds 4 and 2 (each within the scatter of the next).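

Within the data shown here, this is the first change at a single place that can be read in this assay: cyclopropyl in place of isobutyl on a saturated chain carbon bound to an oxygen on a saturated carbon gives a 2.1-fold higher number from compound 1 to compound 4 (0.33 log units; beyond the scatter). The earlier compounds shown here could not show this, as they all differed in more than one place, whereas here everything else is kept and the group at this position alone goes with a modest but real shift in how much compound the cells tolerate. Nothing at hand explains why this exchange moves the number in this direction.

The compounds shown do not separate the presence of the three-membered ring from the loss of the isobutyl group, and a straight propyl chain or a cyclobutyl ring at this place would help tell those two readings apart. As far as these compounds go, it also remains open whether this step would hold with a different group elsewhere on the shared core, or how a longer chain or an amine at this position would fare, since this single pair speaks only for itself.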